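A Chloro Group Added to the Core of Compound 2

The source may hold more compounds than are shown below. What is called first, only, known or untested is meant among the compounds shown, and "the series" means these compounds.

Compound 1 `O=C1Nc2ccccc2/C1=C\c1c(Cl)n(Cc2ccccc2)c2ccccc12` and compound 2 `O=C1Nc2ccccc2/C1=C\c1c(Cl)n(CCCc2ccccc2)c2ccccc12` share a core and differ only in the chain carried on the aromatic nitrogen. In a functional assay on NSCLC cells (Homo sapiens) for cytotoxicity, with a stated time of 48 h (a higher number here means a weaker inhibitor of growth, a lower number a stronger inhibitor of growth), compound 1 gives 14800 nM, and compound 2 gives 14100 nM. The step between them, a 1.0-fold lower number from compound 1 to compound 2 (0.02 log units; within the scatter), shows that lengthening that chain left the growth inhibition essentially unchanged. Compound 3 `COc1ccc2c(c1)/C(=C\c1c(Cl)n(Cc3cc(OC)c(OC)c(OC)c3)c3cc(C)c(OC)cc13)C(=O)N2`, which carries several methoxy groups and a methyl on its rings, gives 20400 nM in this assay; compound 2 stands within the usual scatter of both compound 1 and compound 3, so none of the three can be set apart from the others on these numbers.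

Compound 4 `O=C1Nc2ccc(Cl)cc2/C1=C\c1c(Cl)n(CCCc2ccccc2)c2ccccc12` is not yet measured. It differs from compound 2 by chloro in place of hydrogen on an aromatic carbon. Among the compounds with values here, no measured pair isolates this change: the one step on record, a 1.0-fold lower number from compound 1 to compound 2 (0.02 log units; within the scatter), concerns the chain on the nitrogen, and compound 3 differs from compound 2 in several places at once. With nothing in the data pointing in either direction, compound 4 is expected to show a step of a 1.1-fold lower number from compound 2 to compound 4 (0.04 log units; within the scatter) that stays within the scatter. Compound 4 is therefore estimated at 13000 nM in this assay, with a likely range from 5000 nM to 35000 nM.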

Compound 4, concentration for 50% growth inhibition: 2240 nM
For compound 4 the middle estimate is 5.8-fold (0.76 log units) above the measured one; the whole stated range lies above it.
By their numbers in this assay, from the lowest: compound 4; then compounds 2, 1 and 3 (each within the scatter of the next).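

Chloro in place of hydrogen on an aromatic carbon of a six-membered aromatic ring of carbon only, meta to a fused ring and para to a fused ring, gives in this assay a 6.3-fold lower number from compound 2 to compound 4 (0.80 log units; beyond the scatter), a modest step and the first isolated step here that lies beyond the scatter. Within the data shown here, this place on the shared core therefore responds to a single added heavy atom, whereas the only earlier isolated change, on the chain carried by the aromatic nitrogen, gave a 1.0-fold lower number from compound 1 to compound 2 (0.02 log units; within the scatter). Nothing available here bears on the cause of the chloro step.

The compounds shown leave open whether another group on this same carbon, such as fluoro, bromo, methoxy or an amine, would give a step of similar size or direction, and whether chloro on another carbon of that ring would match it. They also leave open whether the same chloro change would give a comparable step when carried on the chain of compound 1 or on the more heavily substituted rings of compound 3.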